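Moving a fluorine around the phenyl on the piperazine

This account rests on a few compounds, and the source may have more. Where it says the series, first, only, none or still open, it means among the compounds named here.

Compound 1: `CCCn1c(=O)[nH]c2nc(-c3ccc(S(=O)(=O)N4CCN(c5ccc(F)cc5)CC4)cc3)[nH]c2c1=O`, 38%
Compound 2: `CCCn1c(=O)[nH]c2nc(-c3ccc(S(=O)(=O)N4CCN(Cc5cccc(C)c5)CC4)cc3)[nH]c2c1=O`, 17%
Compound 3: `CCCn1c(=O)[nH]c2nc(-c3ccc(S(=O)(=O)N4CCN(c5cccc(Br)c5)CC4)cc3)[nH]c2c1=O`, 27%

Compound 1 stands highest of the three measured compounds in an assay on CHO cells for displacement of a labelled ligand from adenosine receptor A3 (Homo sapiens), read by scintillation counting, with a stated time of 45 min, tested at 1 uM, in the presence of a further agent that is not named here; a higher number here means more inhibition at the concentration tested (going by the name of the read-out), a lower number less inhibition. The nearest to it is compound 3, reached by a number 11 percentage points lower from compound 1 to compound 3 (beyond the scatter), and the furthest is compound 2, reached by a number 21 percentage points lower from compound 1 to compound 2 (beyond the scatter). Between compounds 2 and 3 the difference is a number 10 percentage points higher from compound 2 to compound 3 (within the scatter).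

Compound 4, `CCCn1c(=O)[nH]c2nc(-c3ccc(S(=O)(=O)N4CCN(c5cccc(F)c5)CC4)cc3)[nH]c2c1=O`, has not yet been measured. It differs from compound 1 by 3-fluorophenyl in place of 4-fluorophenyl on an amine nitrogen in a ring. Going by the values given here, the step that bears most closely on this change is the one from compound 1 to compound 3, where another group sitting on the same amine nitrogen in a ring gave a modest loss; the step to compound 2 is a larger change of structure and a larger loss. Both measured steps away from compound 1 went downward, so a modest downward step, or none beyond the scatter, is expected here. Compound 4 is estimated at 30%, between 15% and 45%, which would mean an expected step of a number 8 percentage points lower from compound 1 to compound 4 (within the scatter).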

Compound 4, a percentage reported as inhibition, at one concentration (the size of the read-out at that concentration, not a potency): 44%
For compound 4 the middle estimate is 14 percentage points below the measured one, and the stated range covers the measured number.
By their numbers in this assay, from the lowest: compounds 2 and 3 (each within the scatter of the next); then compounds 1 and 4 (each within the scatter of the next).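

In this assay, 3-fluorophenyl and 4-fluorophenyl on the amine nitrogen in the ring cannot be told apart, with a number 6 percentage points higher from compound 1 to compound 4 (within the scatter) as the step, so this change of fluorine position gives no reading beyond the scatter. Going by these compounds alone, with the substitution position on the phenyl held the same, fluoro in place of bromo on the aromatic carbon gives a number 17 percentage points higher from compound 3 to compound 4 (beyond the scatter) and isolates the substituent as a change that registers here, which the earlier compounds did not do. Replacing 3-methylbenzyl with 3-fluorophenyl gives a number 27 percentage points higher from compound 2 to compound 4 (beyond the scatter) as a further step beyond the scatter.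

Nothing at hand accounts for any of these steps. The compounds shown leave open how a methoxy group or a nitrile on the phenyl would read, and how a pyridine in place of that phenyl would read.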